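Aryl amide variation on the shared core

The source may report more compounds than this note shows. Statements on the series, on what has been measured and on what is new or still open speak of the compounds shown alone.

Compound 1 `CN(C)CCNC(=O)c1c(O)c2cccnc2n(-c2ccccc2)c1=O`: 18.4%
Compound 2 `O=C(Nc1ccc(Cl)cc1)c1c(O)c2cccnc2n(-c2ccccc2)c1=O`: 2.5%

In a functional assay on the whole organism for inhibition, with Rattus norvegicus as the target, read by cytopathic effect and paw edema, at a dose of 100 mg/kg by the oral route (a lower number here means less inhibition, a higher number more inhibition at the dose given (going by the name of the read-out)), compound 2 gives 2.5%, the lower of the two numbers; compound 1 gives 18.4%. Among the measured compounds shown here, the only measured step, a number 15.9 percentage points lower from compound 1 to compound 2 (beyond the scatter), exchanges the whole amide substituent and so bears only loosely on the next change. Compound 3 `Nc1ccc(NC(=O)c2c(O)c3cccnc3n(-c3ccccc3)c2=O)cc1` differs from compound 2 by amino in place of chloro on an aromatic carbon. For the measured compounds named here, no measured step tests this exchange directly. A small rise is expected for compound 3, a number 7.5 percentage points higher from compound 2 to compound 3 (within the scatter), quite possibly within the scatter. Compound 3 is estimated at 10%, with a range from 0% to 28%.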

Compound 3, a percentage reported as inhibition, in the whole organism at one dose (the size of the read-out at that dose, not a potency): 0%
Compound 3: middle estimate off by 10 percentage points, on the high side; measured number inside the range.
By their numbers in this assay, from the lowest: compounds 3 and 2 (each within the scatter of the next); then compound 1.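

Amino in place of chloro on the aromatic carbon para to a large group gives no separation in this assay, with a number 2.5 percentage points lower from compound 2 to compound 3 (within the scatter). Both 4-substituted phenyl amides therefore sit together, and the 4-aminophenyl amide stays apart from the 2-(dimethylamino)ethyl amide, with a number 18.4 percentage points lower from compound 1 to compound 3 (beyond the scatter). No evidence bears on the cause of this result.

Open, on these data alone, is whether a carboxylic acid or a methoxy group at this same position would stand clear of the scatter. Also open, as far as these compounds go, is whether a longer chain ending in dimethylamino on the amide nitrogen would differ from compound 1 at 18.4%.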